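Chromene Triazole Series: Swapping the Amide Substituent

A few compounds are considered here, and "the series" means these few. Any claim that something is new, unique, unknown or untested is made for them only; others in the source may bear on it.

Measured compounds:
Compound 1, `CCOC(=O)C1=Cc2ccccc2OC1(OCc1cn(-c2ccc(F)c([N+](=O)[O-])c2)nn1)C(F)(F)F`, 15600 nM
Compound 2, `CCOC(=O)C1=Cc2ccccc2OC1(OCc1cn(-c2cccc(C(F)(F)F)c2)nn1)C(F)(F)F`, > 150000 nM
Compound 3, `CCOC(=O)C1=Cc2ccccc2OC1(OCc1cn(CC(=O)NC2CCCCC2)nn1)C(F)(F)F`, 11400 nM

All three share one core and differ only in the group on the aromatic nitrogen of the triazole. In a functional assay on HeLa cells (Homo sapiens) for inhibition, read by MTT assay, with a stated time of 24 h (a higher number here means a weaker inhibitor, a lower number a stronger inhibitor), compound 1 gives 15600 nM. For compound 2 the result is a limit of the assay, > 150000 nM, so no number is known for it (the limit of > 150000 nM in this assay, at which 1 of the 3 values shown sits). Compound 3 gives 11400 nM. Within the data shown here, the step of a 1.4-fold lower number from compound 1 to compound 3 (0.14 log units; within the scatter) keeps compound 3 within the scatter of compound 1, so no order between those two can be claimed; the step of an at least 13-fold lower number from compound 2 to compound 3 (1.11 log units; beyond the scatter) is the one large change in the set, and an at least 9.6-fold higher number from compound 1 to compound 2 (0.98 log units; beyond the scatter) is also beyond the scatter.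

Compound 4, `CCOC(=O)C1=Cc2ccccc2OC1(OCc1cn(CC(=O)Nc2ccc(I)cc2Cl)nn1)C(F)(F)F`, changes a different place: 2-chloro-4-iodophenyl in place of cyclohexyl on an amide-type nitrogen. Among the measured compounds shown here, none of the measured steps touches the amide-type nitrogen; they all alter the group on the aromatic nitrogen, so none bears directly on this change. For the measured compounds named here, with no step at this position to lean on, no movement beyond the scatter is expected in this assay.

Compound 4 is therefore expected to give about 12000 nM, with a range from 5000 nM to 30000 nM. This estimate implies a 1.1-fold higher number from compound 3 to compound 4 (0.02 log units; within the scatter).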

Compound 4, half-maximal inhibitory concentration: 26100 nM
Beside the measured number, compound 4's estimate is 2.2-fold (0.34 log units) below it, and the stated range covers the measured number.
By their numbers in this assay, from the lowest: compounds 3, 1 and 4 (each within the scatter of the next, the first and the last beyond it). At a limit, above all of these: compound 2.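

Among these compounds, the amide-type nitrogen, untouched by the earlier steps, turns out to matter in this assay: with 2-chloro-4-iodophenyl in place of cyclohexyl there is a 2.3-fold higher number from compound 3 to compound 4 (0.36 log units; beyond the scatter), a modest step but one beyond the scatter, so this position is not silent. The size of that step stays well short of the largest change at the aromatic nitrogen, and the new compound stays close to the aryl-substituted triazole of the first compound, with a 1.7-fold higher number from compound 1 to compound 4 (0.22 log units; within the scatter), while an at least 5.7-fold lower number from compound 2 to compound 4 (0.75 log units; beyond the scatter) keeps it clearly apart from the 3-(trifluoromethyl)phenyl compound. The value for compound 2 remains a limit and not a number, so that last step has only a lower bound: the limit of > 150000 nM in this assay, at which 1 of the 4 values shown sits.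

The compounds shown leave open whether the step at the amide-type nitrogen follows from the aromatic ring itself or from its chlorine and iodine, a question that a plain phenyl, a 2-chlorophenyl or a 4-iodophenyl group there would address. They also leave open how a cyclopentyl group, or a chain ending in an amine or a carboxylic acid, would read at this nitrogen.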